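Urea series on the shared core: the dichlorophenyl step

The compounds below may be only part of what the source reports. "The series", "measured", "known", "first", "only" and "open" are said of these compounds alone.

Compound 1 `O=C(Nc1ccccc1)Nc1cccc(CNc2nccnc2Cl)c1` carries a plain phenyl on the urea. In a functional assay on T-24 cells (Homo sapiens) for antiproliferative activity, read by MTT assay, with a stated time of 48 h (on this read-out lower numbers stand for stronger inhibition and higher numbers for weaker inhibition), compound 1 gives 19800 nM, the second highest of the three numbers measured. Compound 2 `CN(C)c1ccc(NC(=O)Nc2cccc(CNc3nccnc3Cl)c2)cc1` gives 20200 nM; a 1.0-fold higher number from compound 1 to compound 2 (0.01 log units; within the scatter), so the two values lie within the scatter of each other. Compound 3 `O=C(Nc1cccc(CNc2nccnc2Cl)c1)Nc1ccc(F)c(Cl)c1` gives 4990 nM; a 4.0-fold lower number from compound 1 to compound 3 (0.60 log units; beyond the scatter), and a 4.0-fold lower number from compound 2 to compound 3 (0.61 log units; beyond the scatter). Compound 4 `O=C(Nc1cccc(CNc2nccnc2Cl)c1)Nc1ccc(Cl)c(Cl)c1` is not yet measured. It differs from compound 1 in one place: 3,4-dichlorophenyl in place of phenyl on an amide-type nitrogen. Among the measured compounds shown here, the step that bears on it is the one from compound 1 to compound 3, where a halogenated phenyl also replaced phenyl on the amide-type nitrogen and the number fell by a modest amount beyond the scatter; compound 2 shows that an unhalogenated substitution on that phenyl left the number within the scatter. A step of similar direction and size is therefore expected for compound 4, a 4.0-fold lower number from compound 1 to compound 4 (0.60 log units; beyond the scatter). Compound 4 is expected to give about 5000 nM, with a range from 2000 nM to 12000 nM.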

Compound 4, half-maximal inhibitory concentration: 5210 nM
Compound 4: the middle estimate sits 1.0-fold (0.02 log units) below what was measured; the measured number falls inside the stated range.
By their numbers in this assay, from the lowest: compounds 3 and 4 (each within the scatter of the next); then compounds 1 and 2 (each within the scatter of the next).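

In this assay chloro in place of fluoro on the halogenated phenyl leaves the number unchanged within the scatter (a 1.0-fold higher number from compound 3 to compound 4 (0.02 log units; within the scatter)), so at this position the 3,4-dichlorophenyl and 3-chloro-4-fluorophenyl groups cannot be told apart. The lower number seen with compound 3 is therefore not tied to that one halogen pair, as 3,4-dichlorophenyl also stands beyond the scatter from phenyl (a 3.8-fold lower number from compound 1 to compound 4 (0.58 log units; beyond the scatter)) and from 4-(dimethylamino)phenyl (a 3.9-fold lower number from compound 2 to compound 4 (0.59 log units; beyond the scatter)), a pattern that holds for these four compounds only. No measurement at hand bears on why these steps take the size they do.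

Open, on these data alone, is whether a phenyl with a single chloro keeps the lower number. Also open, as far as these compounds go, is whether a trifluoromethyl, a nitrile or a carboxylic acid on that phenyl groups with the halogens or with the dimethylamino compound.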